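This account rests on a few compounds, and the source may have more. Where it says the series, first, only, none or still open, it means among the compounds named here.

Measured compounds:
compound 1, `Cc1cccc(OC(c2ccc(Br)cc2)C2CCN(C(C)CCNC(=O)c3c(Cl)cncc3Cl)CC2)n1`, 6500 nM
compound 2, `CC(CCNC(=O)c1c(Cl)cncc1Cl)N1CCC(C(Oc2ncccc2Cl)c2ccc(C(F)(F)F)cc2)CC1`, 16700 nM
compound 3, `Cc1cccnc1OC(c1ccc(C(F)(F)F)cc1)C1CCN(C(C)CCNC(=O)c2c(Cl)cncc2Cl)CC1`, 33000 nM

In an ADME assay on PBMC cells (Homo sapiens) for cytotoxicity (a higher number here means that more compound is tolerated, a lower number that less compound is tolerated), compound 3 gives 33000 nM, the highest of the three numbers. Among the compounds with values here, its nearest neighbour is compound 2 at 16700 nM; the one step recorded, a 2.0-fold higher number from compound 2 to compound 3 (0.30 log units; within the scatter), lies within the scatter. Within the data shown here, compound 1 at 6500 nM stands furthest from compound 3, beyond the scatter, but the two differ in more than one place, so no single step is drawn between them.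

Compound 4, `Cc1cccc(OC(c2ccc(C(F)(F)F)cc2)C2CCN(C(C)CCNC(=O)c3c(Cl)cncc3Cl)CC2)n1`, has not yet been measured. It differs from compound 3 by 6-methylpyridin-2-yl in place of 3-methylpyridin-2-yl on an oxygen on a saturated carbon. Among the measured compounds shown here, no measured step isolates this change. Compound 1 carries the 6-methylpyridin-2-yl group and shows the lowest number, yet it also differs from compound 3 elsewhere, so its value cannot be read as a step for this change alone. For the measured compounds named here, the only recorded step, a 2.0-fold higher number from compound 2 to compound 3 (0.30 log units; within the scatter), was within the scatter and concerned a different position.

On this basis the step of a 1.7-fold lower number from compound 3 to compound 4 (0.22 log units; within the scatter) is expected to be small, with a slight lean toward a lower number, given that compound 1 gives 6500 nM. Compound 4 is therefore estimated at 20000 nM, within a range from 7000 nM to 60000 nM.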

Compound 4, half-maximal cytotoxic concentration: 6700 nM
Beside the measured number, compound 4's estimate is 3.0-fold (0.47 log units) above it; measured number outside the range, below it.
By their numbers in this assay, from the lowest: compounds 1 and 4 (each within the scatter of the next); then compounds 2 and 3 (each within the scatter of the next).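

In this assay, within the data shown here, the pyridine change on the oxygen now has a measured step of its own: a 4.9-fold lower number from compound 3 to compound 4 (0.69 log units; beyond the scatter), which lies beyond the scatter, whereas the only earlier step, a 2.0-fold higher number from compound 2 to compound 3 (0.30 log units; within the scatter), concerned the exchange of chloro for methyl on an aromatic carbon and stayed within it. The 6-methylpyridin-2-yl group also separates from the 3-chloropyridin-2-yl group, with a 2.5-fold lower number from compound 2 to compound 4 (0.40 log units; beyond the scatter), so among these compounds it is the group on the oxygen that carries the lower number against both 3-substituted partners, and the change is one of where the methyl sits and not of which atoms are present. With a 1.0-fold higher number from compound 1 to compound 4 (0.01 log units; within the scatter), within the scatter, trifluoromethyl and bromo on the aromatic carbon cannot be told apart here, so the low value of compound 1 goes with its 6-methylpyridin-2-yl group and needs no separate reading of the bromo.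

Nothing available accounts for why the methyl's place matters to this read-out. On these data alone, it remains open where an unsubstituted pyridin-2-yl or a plain phenyl on the same oxygen would fall relative to these two pairs of compounds.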